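One Double Bond Redrawn, With the Read-Out at Its Limit

The source may hold more compounds than are shown below. What is called first, only, known or untested is meant among the compounds shown, and "the series" means these compounds.

Of the compounds shown here, two have been tested so far in an ADME assay on BHK cells (Mesocricetus auratus) for cytotoxicity, read by MTT assay; on this read-out higher numbers stand for lower toxicity in this test and lower numbers for higher toxicity in this test. Compound 1 `OC[C@@H]1[C@@H](O)[C@H](O)[C@@H](O)CN1CCCCCCOc1ccc(OC(F)(F)F)cc1` gives > 500000 nM, which is a limit of the assay and not a number. Compound 2 `OC[C@@H]1[C@@H](O)[C@H](O)[C@@H](O)CN1CC/C=C/CCOc1cc(F)ccc1F` gives > 500000 nM, which is also a limit. Compound 2 therefore has no exact value, and the overall picture is simple: the limit of > 500000 nM in this assay, at which 2 of the 2 values shown sit.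

Compound 3 `OC[C@@H]1[C@@H](O)[C@H](O)[C@@H](O)CN1CC/C=C\CCOc1cc(F)ccc1F` has yet to be measured. Its difference from compound 2 is small: the two compounds have the same atoms and bonds and differ only in configuration as drawn: 1 of 5 stereo elements differ; a double bond is drawn E in compound 2 and Z in compound 3. For the measured compounds named here, no measured pair shows what such a change does in this assay, so no step beyond the usual scatter is expected, in either direction. The expected step of a number no higher from compound 2 to compound 3 (the limit leaves the size open) rests on compound 2 and its limit of > 500000 nM. Compound 3 is estimated at 500000 nM, with an expected range from 250000 nM to 1000000 nM, and it may well be reported only as a limit.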

Compound 3, half-maximal cytotoxic concentration: > 500000 nM
Compound 3: a limit, no number (the forecaster's own chance of this, stated with the estimate: 90%); the middle value sits exactly at the limit.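

Compound 2 and compound 3 are both reported only as limits in this assay, so no step can be read between these two E and Z forms. The compounds shown leave open what structural change, if any, would give an exact number in this assay.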